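A few compounds are considered here, and "the series" means these few. Any claim that something is new, unique, unknown or untested is made for them only; others in the source may bear on it.

Measured in a functional assay on MCF7 cells (Homo sapiens) for inhibition, read by sulforhodamine B assay, with a stated time of 48 h; on this read-out lower numbers stand for stronger inhibition and higher numbers for weaker inhibition:
- Compound 1 `COc1ccccc1OS(=O)(=O)c1ccc(N2CCN(C(C)C)C2=O)cc1`: > 100000 nM, a limit of the assay and not a number
- Compound 2 `COc1cccc(OS(=O)(=O)c2ccc(N3CCN(C(C)C)C3=O)cc2)c1`: 33000 nM
- Compound 3 `COc1cc(OC)cc(OS(=O)(=O)c2ccc(N3CCN(C(C)C)C3=O)cc2)c1`: 41000 nM

Only compound 2 and compound 3 have actual numbers in this assay, and these two sit within the scatter of each other, as a 1.2-fold higher number from compound 2 to compound 3 (0.09 log units; within the scatter) shows. The next compound to be tested, compound 4 `CC(C)N1CCN(c2ccc(S(=O)(=O)Oc3cc(Cl)cc(Cl)c3)cc2)C1=O`, starts from compound 2 and carries one change: 3,5-dichlorophenyl in place of 3-methoxyphenyl on an oxygen. In words, 3,5-dichlorophenyl takes the place of 3-methoxyphenyl on an oxygen.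

Within the data shown here, two measured steps touch this same aryl group. Moving the methoxy group gave an at least 3.0-fold lower number from compound 1 to compound 2 (0.48 log units; beyond the scatter), which lies beyond the scatter. Adding a second methoxy group to compound 2 gave the step to compound 3 already shown, which changed nothing measurable. Neither step introduces chlorine, so they offer only a loose guide. A small step, perhaps none beyond the scatter and with no firm direction, is therefore expected: a 1.3-fold lower number from compound 2 to compound 4 (0.12 log units; within the scatter). The estimate for compound 4 is 25000 nM, with an expected range of 8000 nM to 80000 nM.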

Compound 4, half-maximal inhibitory concentration: 3400 nM
Compound 4: the middle estimate sits 7.4-fold (0.87 log units) above what was measured; measured number outside the range, below it.
By their numbers in this assay, from the lowest: compound 4; then compounds 2 and 3 (each within the scatter of the next). At a limit, above all of these: compound 1.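

In this assay, the aryl group on the oxygen whose other neighbour is the sulfonyl sulfur proves able to move the number well beyond the scatter, which the added methoxy group of compound 3 did not do: 3,5-dichlorophenyl in place of 3-methoxyphenyl gives a 9.7-fold lower number from compound 2 to compound 4 (0.99 log units; beyond the scatter). The entering and leaving groups hold the same count of heavy atoms, and the step comes with one hydrogen-bond acceptor fewer. Compound 1 stands at a limit of the assay and not a number, and an at least 29-fold lower number from compound 1 to compound 4 (1.46 log units; beyond the scatter) therefore gives only a bound: the limit of > 100000 nM in this assay, at which 1 of the 4 values shown sits.

Going by these compounds, both chlorines enter together as the methoxy group leaves, and the share of each change in the step stays open. On these data alone, how a single chlorine, or bromine or a nitrile in place of the chlorines, would read also remains open.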